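The source may report more compounds than this note shows. Statements on the series, on what has been measured and on what is new or still open speak of the compounds shown alone.

Among the compounds with values here, in an ADME assay on J774 cells (Mus musculus) for cytotoxicity (on this read-out higher numbers stand for an effect only at larger amounts of compound and lower numbers for an effect already at smaller amounts), compound 1 (`COC(=O)c1c[nH]c2ccc(OCCCc3ccccc3)cc2c1=O`) gives 17100 nM and compound 2 (`COC(=O)c1c[nH]c2ccc(OC)cc2c1=O`) gives 6180 nM as the lower of the two numbers so far. Compound 3 (`COC(=O)c1c[nH]c2ccc(Oc3ccccc3)cc2c1=O`) is still unmeasured and differs from compound 2 by phenyl in place of methyl on an oxygen on an aromatic ring in a change of phenyl in place of methyl on an oxygen on an aromatic ring. Within the data shown here, the one measured step that bears on this is a 2.8-fold lower number from compound 1 to compound 2 (0.44 log units; beyond the scatter) and there the group on that oxygen becomes smaller. With phenyl as the larger group, a modest rise in this assay is expected, an estimated 1.8-fold higher number from compound 2 to compound 3 (0.25 log units; within the scatter) overall. Compound 3 is estimated at 11000 nM with 4500 nM to 26000 nM as its expected range.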

Compound 3, half-maximal effective concentration: > 20000 nM
Compound 3 gave a limit, no number; the forecaster's own chance of this, stated with the estimate: 10%; at least 1.8-fold (0.25 log units) between middle value and limit.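

In this assay, the change of methoxy to phenoxy gives an at least 3.2-fold higher number from compound 2 to compound 3 (0.51 log units; beyond the scatter), so a phenyl bound directly to this oxygen also moves the number up, as the chain ending in phenyl does in compound 1. Compound 3 stands at a limit, > 20000 nM, and not at a number, so the full size of this rise cannot be read: the limit of > 20000 nM in this assay, at which 1 of the 3 values shown sits.

The compounds shown leave open whether the ring itself matters or only the larger group on this oxygen. On these data alone, how a cyclohexyl group, or a phenyl carrying an amine or a carboxylic acid, would read here also stays open.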